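Oxetane for cyclobutane on the ether side chain

A few compounds are considered here, and "the series" means these few. Any claim that something is new, unique, unknown or untested is made for them only; others in the source may bear on it.

Measured compounds, with their values in a functional assay on cells for antagonist activity at Free fatty acid receptor 1 (Homo sapiens), read by TR-FRET and inositol phosphate accumulation, with a stated time of 2 h; on this read-out lower numbers stand for stronger inhibition and higher numbers for weaker inhibition:
compound 1 `CC1(C)CN(c2cc(COc3ccc(F)c(F)c3F)nc(-c3ccccn3)n2)C1` gives 25.1 nM
compound 2 `CC1(C#N)CN(c2cc(COc3ccc(F)c(F)c3F)nc(-c3ccccn3)n2)C1` gives 158 nM
compound 3 `Fc1ccc(OCc2cc(OCC3CCC3)nc(-c3ccccn3)n2)c(F)c1F` gives 12.6 nM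

Compound 3 carries the lowest number of the three in this assay, but the gap to compound 1 is small: the step of a 2.0-fold lower number from compound 1 to compound 3 (0.30 log units; within the scatter) is within the scatter. The only step beyond the scatter among these is a 13-fold lower number from compound 2 to compound 3 (1.10 log units; beyond the scatter), and it rests on the cyano: the step of a 6.3-fold higher number from compound 1 to compound 2 (0.80 log units; beyond the scatter) shows that placing a polar group on a saturated ring carbon costs a modest amount.

Compound 4 `CC1(COc2cc(COc3ccc(F)c(F)c3F)nc(-c3ccccn3)n2)COC1` differs from compound 3 by 3-methyloxetan-3-yl in place of cyclobutyl on a saturated chain carbon bound to an oxygen on an aromatic ring. For the measured compounds named here, no measured pair shows exactly this swap, so the nearest guide is the step from compound 1 to compound 2, where a heteroatom-bearing group entering a saturated four-membered ring raised the number. On that basis a modest rise is expected in this assay, estimated as a 2.8-fold higher number from compound 3 to compound 4 (0.44 log units; beyond the scatter). Compound 4 is therefore expected to give about 35 nM in this assay, within a range of 12 nM to 120 nM.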

Compound 4, half-maximal inhibitory concentration: 79.4 nM
For compound 4 the middle estimate is 2.3-fold (0.36 log units) below the measured one; measured number inside the range.
By their numbers in this assay, from the lowest: compounds 3 and 1 (each within the scatter of the next); then compounds 4 and 2 (each within the scatter of the next).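

Working notes: in this assay the ether side chain does not tolerate this swap unchanged: 3-methyloxetan-3-yl in place of cyclobutyl gives a 6.3-fold higher number from compound 3 to compound 4 (0.80 log units; beyond the scatter) and brings in one oxygen and one extra carbon at once. Cyclobutylmethoxy stood within the scatter of 3,3-dimethylazetidin-1-yl, but the new side chain does not, giving a 3.2-fold higher number from compound 1 to compound 4 (0.50 log units; beyond the scatter) on that comparison. Against 3-cyano-3-methylazetidin-1-yl the reading is a 2.0-fold lower number from compound 2 to compound 4 (0.30 log units; within the scatter) and places compound 4 level with compound 2 in this assay.

No supporting evidence is available to explain these steps. The compounds shown leave open whether the ring oxygen or the added methyl accounts for the step, a question that oxetan-3-yl or 3-methylcyclobutyl on the same chain would separate.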